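The compounds below may be only part of what the source reports. "The series", "measured", "known", "first", "only" and "open" are said of these compounds alone.

Working notes on the series. The parent, compound 1 `Oc1nc2nonc2nc1Nc1ccccc1`, is the weakest point of reference: in an assay on mitochondria from L6 cells (Rattus norvegicus) for activation, with a stated time of 90 min (on this read-out higher numbers stand for an effect only at larger amounts of compound and lower numbers for an effect already at smaller amounts), compound 1 gives 66700 nM. Two single substitutions on the pendant ring each bring a large gain. Compound 2 `CC(C)(C)c1ccc(Nc2nc3nonc3nc2O)cc1` gives 3900 nM in this assay, and compound 3 `Oc1nc2nonc2nc1Nc1ccccc1Cl` gives 6300 nM. The steps are a 17-fold lower number from compound 1 to compound 2 (1.23 log units; beyond the scatter) and an 11-fold lower number from compound 1 to compound 3 (1.02 log units; beyond the scatter). Compound 2 thus holds the lowest number of the three, although the gap between compound 2 and compound 3 lies within the scatter, so no order between those two can be claimed.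

The next step is from compound 2 to compound 4 `Oc1nc2nonc2nc1Nc1ccc(OC(F)(F)C(F)F)cc1`, which has not yet been measured in this assay. The change is 1,1,2,2-tetrafluoroethoxy in place of tert-butyl on an aromatic carbon; the entering 1,1,2,2-tetrafluoroethoxy sits on an aromatic carbon of a six-membered aromatic ring of carbon only, para to a large group. Among the compounds with values here, no measured step covers an exchange of one substituent for another at this place; the bearing steps are those from the bare ring, both large and both toward lower numbers, which show that a group here is worth much compared with hydrogen. Going by these compounds, whether tetrafluoroethoxy matches tert-butyl is untested. For compound 4 the expected step is a 1.3-fold higher number from compound 2 to compound 4 (0.11 log units; within the scatter), that is, no change beyond the scatter. The estimate for compound 4 in this assay is 5000 nM, with a range from 1500 nM to 16000 nM.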

Compound 4, half-maximal effective concentration: 7000 nM
Estimate against measurement, compound 4: 1.4-fold (0.15 log units) below; low and high end bracket the measured number.
By their numbers in this assay, from the lowest: compounds 2, 3 and 4 (each within the scatter of the next); then compound 1.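

Within the data shown here, compound 4 supplies what the earlier compounds lacked, an exchange of one group for another at this place rather than a group for hydrogen: in this assay the step is a 1.8-fold higher number from compound 2 to compound 4 (0.25 log units; within the scatter) and so gives no ground to separate 1,1,2,2-tetrafluoroethoxy from tert-butyl, although the entering group brings oxygen, fluorine and one hydrogen-bond acceptor where the leaving group has carbon alone and no acceptor. The gain over the bare ring also holds for the new group, with a 9.5-fold lower number from compound 1 to compound 4 (0.98 log units; beyond the scatter) and thus beyond the scatter, so at this place it is not tied to tert-butyl alone. No measurement on hand bears on why these two groups give results within the scatter of each other.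

Going by these compounds, whether a carboxylic acid, an amine or a longer chain such as n-butoxy on this aromatic carbon would keep the number in this range stays open. Also open, on these data alone, is whether the chloro of compound 3, combined with tert-butyl or 1,1,2,2-tetrafluoroethoxy on the same ring, would go further than either substitution alone.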